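A few compounds are considered here, and "the series" means these few. Any claim that something is new, unique, unknown or untested is made for them only; others in the source may bear on it.

Values in a functional assay on A2780 cells (Homo sapiens) for cytotoxicity, read by MTT assay, with a stated time of 68 h; a higher number here means a weaker inhibitor, a lower number a stronger inhibitor:

Compound 1 `O=C(/C=C/c1cccc(OCc2ccccc2)c1)c1ccc([N+](=O)[O-])cc1`: 56400 nM
Compound 2 `O=C(/C=C/c1cccc(OCc2ccccc2)c1)c1ccc(Br)cc1`: 1800 nM
Compound 3 `O=C(/C=C/c1cccc(OCc2ccccc2)c1)c1ccccc1Br`: 2500 nM
Compound 4 `O=C(/C=C/c1cccc(OCc2ccccc2)c1)c1ccccc1`: not yet measured

Of the three measured compounds, compound 1 has the highest number, which makes it the weakest inhibitor of the set in this assay. Its gaps to the other two both lie beyond the scatter. Going to compound 4 makes one change, hydrogen in place of nitro on an aromatic carbon, which turns the 4-nitrophenyl into a phenyl.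

The closest measured step is a 31-fold lower number from compound 1 to compound 2 (1.50 log units; beyond the scatter), which puts bromo in place of nitro at the same carbon and is large. The step of a 23-fold lower number from compound 1 to compound 3 (1.35 log units; beyond the scatter), with 2-bromophenyl in place of 4-nitrophenyl, is also large. The step of a 1.4-fold higher number from compound 2 to compound 3 (0.14 log units; within the scatter) stays within the scatter, so the two bromo compounds give no separate signal. Among the measured compounds shown here, both large steps remove the nitro, but both also add a bromo, and no measured compound shows the effect of removing the nitro alone. A large step to a lower number is therefore expected, possibly somewhat smaller than those two. For compound 4 the estimated value is 4000 nM, within a range of 1300 nM to 15000 nM. The expected change is a 14-fold lower number from compound 1 to compound 4 (1.15 log units; beyond the scatter).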

Compound 4, half-maximal inhibitory concentration: 6700 nM
Compound 4: middle estimate off by 1.7-fold (0.22 log units), on the low side, and the stated range covers the measured number.
By their numbers in this assay, from the lowest: compounds 2 and 3 (each within the scatter of the next); then compound 4; then compound 1.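

Among the compounds shown here, the step of an 8.4-fold lower number from compound 1 to compound 4 (0.93 log units; beyond the scatter) in this assay isolates the nitro for the first time: taking it off, with nothing added in its place, already lowers the number well beyond the scatter, though the change is only modest in size. Compound 4 also gives the bromo compounds a bare phenyl reference, and the steps of a 3.7-fold higher number from compound 2 to compound 4 (0.57 log units; beyond the scatter) and a 2.7-fold higher number from compound 3 to compound 4 (0.43 log units; beyond the scatter) show that hydrogen in place of bromo raises the number at both carbons tested. The large drop from nitro to bromo therefore has two parts, one from losing the nitro and one from gaining a bromo, and no measurement shown here explains either part.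

With only nitro, bromo and hydrogen shown on this ring, it remains open where an amine, a methoxy group or a carboxylic acid would fall among these compounds. Going by these compounds, the nitro also appears at just one carbon, so whether removing it from another carbon of the ring would produce a similar change remains unknown.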